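The compounds below may be only part of what the source reports. "The series", "measured", "known", "first", "only" and "open" are said of these compounds alone.

Working notes on the series. Compound 1 `CC(C)(C)c1ccc(-c2nnc(SCCCN3CCN(c4ccccc4)CC3)[nH]2)cc1` gives the first data point. In a functional assay on MCF7 cells (Homo sapiens) for cytotoxicity, read by MTT assay, with a stated time of 24 h (on this read-out higher numbers stand for weaker inhibition and lower numbers for stronger inhibition), compound 1 reaches only the limit of the assay, > 300000 nM. Compound 2 `Cc1ccc(-c2nnc(SCCCN3CCN(c4cccc(Cl)c4)CC3)[nH]2)cc1` carries a 3-chlorophenyl on the ring amine nitrogen. In this assay compound 2 likewise returns only a limit, > 300000 nM. Where compound 2 stands on the numbers so far: the limit of > 300000 nM in this assay, at which 2 of the 2 values shown sit, so no order among the measured compounds can be given, and no step between measured compounds exists to draw on. Compound 3 `CCN1CCN(CCCSc2nnc(-c3ccc(C)cc3)[nH]2)CC1` is the next candidate; its change from compound 2 is ethyl in place of 3-chlorophenyl on an amine nitrogen in a ring. For the measured compounds named here, no measured step informs this change, and with both measured compounds sitting at the limit, no movement beyond the scatter is expected in either direction in this assay. For compound 3 the estimate is 300000 nM, with a range from 150000 nM to 600000 nM. The step this estimate means is expected to be a number no higher from compound 2 to compound 3 (the limit leaves the size open), most likely reported once more as a limit rather than a number.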

Compound 3, half-maximal inhibitory concentration: > 300000 nM
Compound 3 ended at the assay's limit (the forecaster's own chance of this, stated with the estimate: 80%); the middle value lies on the limit itself.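

Compound 3 returns only a limit in this assay, > 300000 nM, and compound 2 also stands at a limit, so no step can be read between these two compounds. The compounds shown leave open how they rank and whether the group on the amine nitrogen in the ring changes the read-out at all: the limit of > 300000 nM in this assay, at which 3 of the 3 values shown sit.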